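This account rests on a few compounds, and the source may have more. Where it says the series, first, only, none or still open, it means among the compounds named here.

Compound 1 `CCCC(=O)Nc1ccc(Oc2cccc(OC)c2)cc1` gives 0.75 nM in an assay on isolated protein for binding affinity to melatonin receptor type 1B (Homo sapiens); a lower number here means a stronger inhibitor, a higher number a weaker inhibitor; compound 2 `COc1cccc(Oc2ccc(NC(C)=O)cc2)c1` gives 4.1 nM; compound 3 `COc1cccc(N(C)c2ccc(NC(C)=O)cc2)c1` gives 0.23 nM.

Compound 3 thus stands lowest of the three numbers in this assay, with compound 1 nearest and compound 2 furthest from it. Compound 4 `CCOC(=O)Nc1ccc(N(C)c2cccc(OC)c2)cc1` differs from compound 3 in one place: ethoxy in place of methyl on a carbonyl carbon, which reads acetamido to (ethoxycarbonyl)amino. Within the data shown here, the only measured step that bears on this part of the molecule is a 5.5-fold higher number from compound 1 to compound 2 (0.74 log units; beyond the scatter), showing that the group on the carbonyl carbon shifts the number beyond the scatter. Among the measured compounds shown here, no measured pair exchanges methyl for ethoxy, so the direction is uncertain. A modest rise is expected, a 4.3-fold higher number from compound 3 to compound 4 (0.64 log units; beyond the scatter). Compound 4 is therefore estimated at 1 nM, with a range from 0.2 nM to 6 nM.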

Compound 4, inhibition constant: 7.2 nM
Estimate against measurement, compound 4: 7.2-fold (0.86 log units) below; measured number above the stated range.
By their numbers in this assay, from the lowest: compound 3; then compound 1; then compounds 2 and 4 (each within the scatter of the next).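

In this assay, replacing methyl with ethoxy on this carbonyl carbon gives a 31-fold higher number from compound 3 to compound 4 (1.50 log units; beyond the scatter), a large step. Among these compounds, this is the first direct reading of the acetamido to (ethoxycarbonyl)amino change, and it shows that on the core of compound 3 this change raises the number. Nothing measured here accounts for the rise.

The compounds shown leave open whether the rise follows the added oxygen or the longer group, which an ethyl or a methoxy group on the same carbonyl carbon could separate. They also leave open whether the same change raises the number on the core of compound 2.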